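This account rests on a few compounds, and the source may have more. Where it says the series, first, only, none or still open, it means among the compounds named here.

Working notes on the series. In an ADME assay on L1210/0 cells (Mus musculus) for cytotoxicity, with a stated time of 48 h (a lower number here means a stronger inhibitor, a higher number a weaker inhibitor), compound 2 `OC[C@H]1C[C@@H](Cn2cnc3c(-c4ccccc4)ncnc32)c2ccccc21` gives 28100 nM, the highest of the two numbers shown; compound 3 `Nc1ncnc2c1ncn2[C@H]1C[C@@H](O)[C@@H](C=O)O1` gives 26600 nM, which sits within the scatter of compound 2. Compound 1 `O[C@H]1C[C@@H](Cn2cnc3c(-c4ccccc4)ncnc32)c2ccccc21` returns only a limit, > 200000 nM, and that is the limit of > 200000 nM in this assay, at which 1 of the 3 values shown sits. For the measured compounds named here, the single measured step, an at least 7.1-fold lower number from compound 1 to compound 2 (0.85 log units; beyond the scatter), concerns a saturated ring carbon and not the aromatic carbon changed here. Compound 4 `OC[C@H]1C[C@@H](Cn2cnc3c(O)ncnc32)c2ccccc21` differs from compound 2 by hydroxy in place of phenyl on an aromatic carbon. Going by the values given here, no measured step addresses hydroxy in place of phenyl on an aromatic carbon, so nothing in the data fixes the size or direction; the expectation is a weaker number, with a real chance that only a limit is returned. Compound 4 is estimated at 80000 nM, within 20000 nM to 250000 nM. The expected step is a 2.8-fold higher number from compound 2 to compound 4 (0.45 log units; beyond the scatter).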

Compound 4, half-maximal inhibitory concentration: > 200000 nM
Compound 4: only a limit was reported (the forecaster's own chance of this, stated with the estimate: 35%); middle value at least 2.5-fold (0.39 log units) from the limit.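

For the compounds shown here, at this aromatic carbon, hydroxy in place of phenyl gives in this assay an at least 7.1-fold higher number from compound 2 to compound 4 (0.85 log units; beyond the scatter), the first measured step here, which fixes its direction but only bounds its size. Compound 4 returns only a limit, the same one as compound 1: the limit of > 200000 nM in this assay, at which 2 of the 4 values shown sit. Of the three compounds sharing this core, compound 2 alone now gives a number rather than a limit, so changing either the hydroxymethyl or the phenyl loses it.

Going by these compounds, the true size of the step stays unknown. Also open, on these data alone, is whether an amine, a methyl or a substituted phenyl on this carbon would keep a measurable number.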